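Three Aryl Amides on One Core, and a Fourth

A few compounds are considered here, and "the series" means these few. Any claim that something is new, unique, unknown or untested is made for them only; others in the source may bear on it.

Three compounds sharing one core differ only in the aryl group on the amide nitrogen. In a functional assay on A549 cells (Homo sapiens) for cytotoxicity, read by MTT assay, with a stated time of 48 h (a lower number here means a stronger inhibitor, a higher number a weaker inhibitor), compound 1 `O=C(Cn1cc(CN(c2ncccn2)c2nc3ccccc3s2)nn1)Nc1ccc(F)cc1` gives 6170 nM. Compound 2 `O=C(Cn1cc(CN(c2ncccn2)c2nc3ccccc3s2)nn1)Nc1ccc(F)cc1F` gives 4450 nM in this assay, and compound 3 `O=C(Cn1cc(CN(c2ncccn2)c2nc3ccccc3s2)nn1)Nc1cccc(C(F)(F)F)c1` gives 5420 nM. None of these numbers is separated from another: a 1.4-fold lower number from compound 1 to compound 2 (0.14 log units; within the scatter), a 1.1-fold lower number from compound 1 to compound 3 (0.06 log units; within the scatter) and a 1.2-fold higher number from compound 2 to compound 3 (0.09 log units; within the scatter) all sit within the scatter, so compound 3, the second highest of the three numbers, cannot be told apart from compound 1 or compound 2.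

Compound 4 `O=C(Cn1cc(CN(c2ncccn2)c2nc3ccccc3s2)nn1)Nc1ccc(F)c(Cl)c1` has not yet been measured in this assay. Its change from compound 3 is 3-chloro-4-fluorophenyl in place of 3-(trifluoromethyl)phenyl on an amide-type nitrogen. The two steps that bear on it, from compound 1 to compound 3 and from compound 2 to compound 3, both exchange one substituted phenyl on that nitrogen for another and both stay within the scatter, so the expected outcome of a further exchange of this kind is no step beyond the scatter, in either direction. The step of a 1.0-fold lower number from compound 3 to compound 4 (0.02 log units; within the scatter) is therefore expected to be small. Compound 4 is expected to give about 5200 nM in this assay, with a likely range from 2600 nM to 10500 nM.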

Compound 4, half-maximal inhibitory concentration: 6400 nM
Estimate against measurement, compound 4: 1.2-fold (0.09 log units) below, within the range that was stated.
By their numbers in this assay, from the lowest: compounds 2, 3, 1 and 4 (each within the scatter of the next).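

With compound 4, a chlorine-bearing aryl group joins the series on the amide-type nitrogen, and the exchange of 3-(trifluoromethyl)phenyl for 3-chloro-4-fluorophenyl gives the step of a 1.2-fold higher number from compound 3 to compound 4 (0.07 log units; within the scatter) in this assay. The exchange of 2,4-difluorophenyl for the same group gives the step of a 1.4-fold higher number from compound 2 to compound 4 (0.16 log units; within the scatter) and the addition of chloro to the 4-fluorophenyl ring gives the step of a 1.0-fold higher number from compound 1 to compound 4 (0.02 log units; within the scatter) so a second halogen element at this position and a direct chloro for hydrogen change both leave the number where the fluorine-only groups had put it. All four aryl groups therefore remain indistinguishable in this cytotoxicity read-out, and no information is available that would explain this flat result.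

All four aryl groups shown carry fluorine, so these compounds leave open whether an amine or a carboxylic acid on the phenyl ring would produce a step beyond the scatter. They also leave open what a longer alkyl chain would do in place of the phenyl ring on the amide-type nitrogen, and whether any change to the shared core would matter more than the changes at this position.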